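The source may report more compounds than this note shows. Statements on the series, on what has been measured and on what is new or still open speak of the compounds shown alone.

Measured so far in a functional assay on A549 cells (Homo sapiens) for inhibition; on this read-out lower numbers stand for stronger inhibition and higher numbers for weaker inhibition:

- compound 1, `CC(C)(C)NC(=O)N1CC1C#N`: 180000 nM
- compound 2, `N#CC1CN1C(=O)Nc1cccc2ccccc12`: 2500 nM
- compound 3, `N#CC1CN1C(=O)Nc1cccnc1`: 16000 nM

Compound 1 stands at the highest of the three numbers. Compound 3 lies beyond the scatter below it, and compound 2 lies further below still, so compound 1 is the weakest of the three in this assay.

Compound 4, `CNC(=O)N1CC1C#N`, is not yet measured. It differs from compound 1 by methyl in place of tert-butyl on an amide-type nitrogen. For the measured compounds named here, no measured pair shows this change, and the two aryl ureas differ from compound 1 in another place, so they give no direct guide. The step from compound 1 to compound 4 is expected to stay within the scatter, if anything toward a higher number: a 1.4-fold higher number from compound 1 to compound 4 (0.14 log units; within the scatter). For compound 4 the estimate is 250000 nM, with a range from 80000 nM to 800000 nM.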

Compound 4, half-maximal inhibitory concentration: 22000 nM
Beside the measured number, compound 4's estimate is 11-fold (1.06 log units) above it; the whole stated range lies above it.
By their numbers in this assay, from the lowest: compound 2; then compounds 3 and 4 (each within the scatter of the next); then compound 1.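

In this assay, methyl in place of tert-butyl on an amide-type nitrogen gives an 8.2-fold lower number from compound 1 to compound 4 (0.91 log units; beyond the scatter). For the compounds shown here, this is the only single-place step, and it shows that the group at this position affects the read-out, with methyl carrying the stronger inhibition of the two. Nothing available explains the step.

Two alkyl groups cannot show whether the value changes steadily with chain length, so ethyl or isopropyl on the same nitrogen would be informative. From the compounds shown here alone, the effect of a longer chain ending in an amine or a carboxylic acid remains open.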